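Adding a Short Chain Where a Longer One Was Removed

The source may report more compounds than this note shows. Statements on the series, on what has been measured and on what is new or still open speak of the compounds shown alone.

Measured so far:
compound 1 `CC(C)=CCC/C(C)=C/CC/C(C)=C/C(=O)NC(=N)NC(=O)/C=C(\C)CC/C=C(\C)CCC=C(C)C` — 5700 nM
compound 2 `CC(C)=CCC/C(C)=C/CC/C(C)=C/C(=O)NC(=N)NC(=O)C=C(C)C` — 7500 nM

Going by the values given here, in a functional assay on B16-F10 cells (Mus musculus) for inhibition, read by MTT assay, with a stated time of 72 h (on this read-out lower numbers stand for stronger inhibition of growth and higher numbers for weaker inhibition of growth), compound 2 gives the higher of the two numbers, but its only neighbour sits close: the single measured step, a 1.3-fold higher number from compound 1 to compound 2 (0.12 log units; within the scatter), stays within the scatter of this assay, so the two compounds cannot be ranked.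

Compound 3 `CC(C)=CCC/C(C)=C/CC/C(C)=C/C(=O)NC(=N)NC(=O)/C=C(\C)CCC=C(C)C` is the next compound to be tested. It differs from compound 2 by 3-methylbut-2-en-1-yl in place of hydrogen on a saturated chain carbon bound to a double-bonded chain carbon. This is a partial reversal of the measured step, which took away a longer chain from the same kind of position and gave a 1.3-fold higher number from compound 1 to compound 2 (0.12 log units; within the scatter), a change too small to count. A chain shorter than the one removed, put back at that place, is therefore expected to leave the number essentially where it is, with an estimated step of a 1.2-fold lower number from compound 2 to compound 3 (0.06 log units; within the scatter). Compound 3 is expected to give about 6500 nM, with a likely range from 3000 nM to 13000 nM.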

Compound 3, concentration for 50% growth inhibition: 18900 nM
The estimate for compound 3 lay 2.9-fold (0.46 log units) below the measured number; measured number above the stated range.
By their numbers in this assay, from the lowest: compounds 1 and 2 (each within the scatter of the next); then compound 3.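

In this assay, this place turns out not to be indifferent to what sits on it: 3-methylbut-2-en-1-yl in place of hydrogen gives a 2.5-fold higher number from compound 2 to compound 3 (0.40 log units; beyond the scatter) and so moves the number beyond the scatter, while the longer chain of compound 1 also stands apart, with a 3.3-fold higher number from compound 1 to compound 3 (0.52 log units; beyond the scatter) on going to the shorter chain. Compound 1 and compound 2 cannot be ranked, so the number does not follow chain length across these three compounds: only the middle-sized chain of compound 3 stands apart, while hydrogen and the longest chain cannot be told apart. Nothing available explains this pattern.

The compounds shown leave open whether the double bond of the entering chain matters or only its size. A saturated 3-methylbutyl chain at the same place would address that, and a chain ending in an amine would show how far this place tolerates a different kind of group.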